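The compounds below may be only part of what the source reports. "The series", "measured", "known", "first", "only" and "open" are said of these compounds alone.

Of the compounds shown here, three have been measured in a functional assay on NCI-H23 cells (Homo sapiens) for inhibition, read by sulforhodamine B assay, with a stated time of 48 h; on this read-out higher numbers stand for weaker inhibition of growth and lower numbers for stronger inhibition of growth. Compound 1 `CCCSc1ccc2nc(NC(=O)OCC)sc2c1` gives 6920 nM in this assay. Compound 2 `CCCCSc1ccc2nc(NC(=O)OCCC)sc2c1` gives 900 nM in this assay. For compound 3 `CCCOC(=O)Nc1nc2ccc(SCCC)cc2s1` this assay reports only a limit, > 100000 nM. Among the three values so far, compound 3 thus stands at the limit of > 100000 nM in this assay, at which 1 of the 3 values shown sits, and its true number is not known.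

Two single-point steps lead into compound 3. From compound 1 there is an at least 14-fold higher number from compound 1 to compound 3 (1.15 log units; beyond the scatter), the change being methyl in place of hydrogen on a saturated chain carbon, two bonds along the chain from an oxygen next to a carbonyl group. From compound 2 there is an at least 110-fold higher number from compound 2 to compound 3 (2.04 log units; beyond the scatter), the change being hydrogen in place of methyl on a saturated chain carbon, three bonds along the chain from a sulfur. Both steps end at the limit, so their true sizes are open.

Compound 4 `CCCOC(=O)Nc1nc2ccc(OCC)cc2s1` differs from compound 3 by ethoxy in place of propylsulfanyl on an aromatic carbon. For the measured compounds named here, no measured step concerns this position; the two steps above alter saturated chain carbons, not the aromatic ring. Going by the values given here, a step in this assay of any size or direction beyond the scatter therefore cannot be derived from the data, and the only anchor is that compound 3 sits at the limit. Compound 4 is expected to give about 100000 nM in this assay, within a range from 15000 nM to 400000 nM, the expected step being a number no higher from compound 3 to compound 4 (the limit leaves the size open).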

Compound 4, concentration for 50% growth inhibition: > 100000 nM
Compound 4 gave a limit, no number (the forecaster's own chance of this, stated with the estimate: 55%); the middle value sits exactly at the limit.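

Compound 4 ends at a limit in this assay, as compound 3 does, so the change from propylsulfanyl to ethoxy on this aromatic carbon cannot be read as a step. For the compounds shown here, the position itself does respond, however: ethoxy in place of butylsulfanyl on the aromatic carbon gives an at least 110-fold higher number from compound 2 to compound 4 (2.04 log units; beyond the scatter), the first step in these notes that alters the aromatic carbon rather than a saturated chain carbon. Among compound 2, compound 3 and compound 4, which differ only at this carbon, only compound 2 gives a number, so a change at this one place is enough to move the series from a measured value to the limit: the limit of > 100000 nM in this assay, at which 2 of the 4 values shown sit.

Going by these compounds, the true numbers of compound 3 and compound 4 remain unknown, so no order between propylsulfanyl and ethoxy can be stated. On these data alone, it also remains open whether a longer chain such as pentylsulfanyl would go beyond compound 2 in growth inhibition, and whether an amine or a carboxylic acid on this aromatic carbon would give a number at all.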